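The source may report more compounds than this note shows. Statements on the series, on what has been measured and on what is new or still open speak of the compounds shown alone.

Series notes. Compound 1 `CCCCCCCCCCCCSC[C@H](NC(C)=O)C(=O)CCl` gives 2000 nM in a functional assay on NALM-6 cells (Homo sapiens); a higher number here means a weaker inhibitor, a lower number a stronger inhibitor. Compound 2 `CCCCCCCCCCCCCSC[C@H](NC(C)=O)C(=O)CCl` differs from compound 1 by methyl in place of hydrogen on a saturated chain carbon, ten or more bonds along the chain from a sulfur. In this assay compound 2 returns only a limit, > 100000 nM, not a number. The step of an at least 50-fold higher number from compound 1 to compound 2 (1.69 log units; beyond the scatter) therefore rests on (the limit of > 100000 nM in this assay, at which 1 of the 3 values shown sits). Compound 3 `CCCCCCCCCCCCCCCSC[C@H](NC(C)=O)C(=O)CCl` differs from compound 1 by propyl in place of hydrogen on a saturated chain carbon, ten or more bonds along the chain from a sulfur; in this assay compound 3 gives 8900 nM. That yields a 4.5-fold higher number from compound 1 to compound 3 (0.65 log units; beyond the scatter) and an at least 11-fold lower number from compound 2 to compound 3 (1.05 log units; beyond the scatter). Compound 4 `CCCCCCCCCCCCCCCCSC[C@H](NC(C)=O)C(=O)CCl` differs from compound 3 by methyl in place of hydrogen on a saturated chain carbon, ten or more bonds along the chain from a sulfur, the same change as from compound 1 to compound 2. Within the data shown here, with only one earlier instance of this change, and that one ending at a limit, the expected step of a 4.5-fold higher number from compound 3 to compound 4 (0.65 log units; beyond the scatter) is taken as a worsening of uncertain size. Compound 4 is thus estimated at 40000 nM, expected to fall between 8000 nM and 200000 nM.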

Compound 4, half-maximal inhibitory concentration: 16000 nM
The estimate for compound 4 lay 2.5-fold (0.40 log units) above the measured number; the range from low to high includes it.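

In this assay, a 1.8-fold higher number from compound 3 to compound 4 (0.25 log units; within the scatter) does not repeat the size of the methyl step on the other core: the same change on two cores in this assay, an at least 50-fold higher number (1.69 log units; beyond the scatter) from compound 1 to compound 2 and a 1.8-fold higher number (0.25 log units; within the scatter) from compound 3 to compound 4, at least 27-fold (1.44 log units) apart, beyond the scatter of two such steps. The propyl change, now also read as an at least 6.2-fold lower number from compound 2 to compound 4 (0.79 log units; beyond the scatter), does not hold its size from one core to another either: the same change on two cores in this assay, a 4.5-fold higher number (0.65 log units; beyond the scatter) from compound 1 to compound 3 and an at least 6.2-fold lower number (0.79 log units; beyond the scatter) from compound 2 to compound 4, at least 27-fold (1.44 log units) apart, beyond the scatter of two such steps. Both gaps are minimum gaps, and their true sizes are not shown, as compound 2 returns only a limit: the limit of > 100000 nM in this assay, at which 1 of the 4 values shown sits.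

From the compounds shown here alone, the butyl change, an 8.0-fold higher number from compound 1 to compound 4 (0.90 log units; beyond the scatter), has a single instance, so whether it carries over to another core stays open. Also open, going by these compounds, is what a longer chain, or an amine in place of the chloromethyl ketone's chlorine, would give.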